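Swapping a saturated ring for an aromatic one

The compounds below may be only part of what the source reports. "The series", "measured", "known", "first", "only" and "open" are said of these compounds alone.

Measured so far:
- compound 1, `CN1CCC(S(=O)(=O)c2ccc3nc(NC(=O)NC(=O)c4cc(N5CCCC5)ccc4Cl)sc3c2)CC1`: 0.92 nM
- compound 2, `CN1CCC(S(=O)(=O)c2ccc3nc(NC(=O)NC(=O)c4cc(N5CCCC5)c(C#N)cc4Cl)sc3c2)CC1`: 0.4 nM
- compound 3, `Cc1ccn(-c2ccc(Cl)c(C(=O)NC(=O)Nc3nc4ccc(S(=O)(=O)CCCN5CCN(C)CC5)cc4s3)c2)n1`: 0.53 nM

All three were tested in an assay on HEK293 cells for displacement of a labelled ligand from growth hormone secretagogue receptor type 1 (Homo sapiens), with a stated time of 60 min; a higher number here means a weaker inhibitor, a lower number a stronger inhibitor. Among the three numbers, compound 1 has the highest; compound 3 is nearest to it and the two lie within the usual scatter, so no order between them can be claimed, while compound 2 is furthest and its step of a 2.3-fold lower number from compound 1 to compound 2 (0.36 log units; beyond the scatter) is beyond the scatter.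

Compound 4, `CN1CCC(S(=O)(=O)c2ccc3nc(NC(=O)NC(=O)c4cc(-n5cccn5)ccc4Cl)sc3c2)CC1`, is not yet measured. Compared with compound 1 it carries 1H-pyrazol-1-yl in place of pyrrolidin-1-yl on an aromatic carbon.

Among the measured compounds shown here, only one measured step is available, a 2.3-fold lower number from compound 1 to compound 2 (0.36 log units; beyond the scatter), and it concerns a different change, so it does not bear directly on the present one. For the measured compounds named here, compound 3 also carries a pyrazole-type group on its chlorophenyl part, and its value of 0.53 nM sits within the scatter of the value of compound 1; no step between them is given, so only this closeness can be read. Taken together, the expectation for compound 4 is a step of a 1.3-fold lower number from compound 1 to compound 4 (0.12 log units; within the scatter) that stays within the usual scatter. Compound 4 is therefore estimated at 0.7 nM, with a likely range from 0.3 nM to 1.8 nM.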

Compound 4, half-maximal inhibitory concentration in the growth hormone secretagogue receptor type 1 assay: 15 nM
Compound 4: the middle estimate sits 21-fold (1.33 log units) below what was measured; measured number outside the range, above it.
By their numbers in the growth hormone secretagogue receptor type 1 assay, from the lowest: compounds 2, 3 and 1 (each within the scatter of the next, the first and the last beyond it); then compound 4.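

In the growth hormone secretagogue receptor type 1 assay, a 16-fold higher number from compound 1 to compound 4 (1.21 log units; beyond the scatter), so this position clearly tells the two five-membered rings apart, although 1H-pyrazol-1-yl and pyrrolidin-1-yl each hold 5 heavy atoms and sit on the same aromatic carbon, para to a chloro group. The change also shows up in a second read-out: in a physicochemical assay for lipophilicity (on this read-out lower numbers stand for lower lipophilicity and higher numbers for higher lipophilicity), compound 1 gives 3.1 and compound 4 gives 2.5. The aromatic ring therefore comes with lower lipophilicity alongside the weaker binding, although a single pair cannot show that one causes the other: the measured distribution coefficient of compound 1, 3.1, and of compound 4, 2.5, a number 0.60 log units lower (beyond the scatter)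

From the compounds shown here alone, with only these two rings compared at this position on an otherwise unchanged structure, it remains open whether the loss follows from aromaticity itself or from the second ring nitrogen. A dimethylamino group, a piperidine or a morpholine on the same carbon would show how much of the binding depends on a saturated amine there, and an imidazole or a pyrrole would test the aromatic side.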